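The source may report more compounds than this note shows. Statements on the series, on what has been measured and on what is new or still open speak of the compounds shown alone.

Compound 1 `CCCCNCCOc1c(O)cc(O)c2c(=O)cc(-c3ccccc3)oc12`: "not determined" (no result reported) in a functional assay on A549 cells (Homo sapiens) for cytotoxicity, read by MTT assay, with a stated time of 48 h; on this read-out higher numbers stand for weaker inhibition and lower numbers for stronger inhibition
Compound 2 `COc1c(OCc2ncc(C)o2)cc(O)c2c(=O)cc(-c3ccccc3)oc12`: > 100000 nM in this assay, which is a limit of the assay rather than a number
Compound 3 `COc1c(O)cc(O)c2c(=O)cc(-c3cccc(F)c3)oc12`: "not determined" (no result reported) in this assay

Compound 1 therefore stands without a number of its own; among the three results shown, one is a limit and one more is without a result, so no measured step exists to set a scale. Compound 4 `CN(C)CCCOc1c(O)cc(O)c2c(=O)cc(-c3ccccc3)oc12` differs from compound 1 by (dimethylamino)methyl in place of butylamino on a saturated chain carbon, two bonds along the chain from an oxygen on an aromatic ring. Going by the values given here, with no comparison between measured compounds, no size or direction can be read for this change, and the only anchor is the line (the limit of > 100000 nM in this assay, at which 1 of the 3 values shown sits), at which compound 2 sits. Compound 4 is expected to inhibit weakly, estimated at 30000 nM, within a range from 8000 nM to 100000 nM.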

Compound 4, half-maximal inhibitory concentration: > 100000 nM
Compound 4: a limit, no number; the forecaster's own chance of this, stated with the estimate: 35%; middle value at least 3.3-fold (0.52 log units) away from the limit.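

Compound 4 gives > 100000 nM in this assay, which is a limit and not a number. Compound 1 has no number here, so no step can be read between them. The compounds shown leave open whether swapping butylamino for (dimethylamino)methyl changes inhibition at all.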